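From 4-fluorophenyl to 4-methoxyphenyl: working notes

The source may hold more compounds than are shown below. What is called first, only, known or untested is meant among the compounds shown, and "the series" means these compounds.

compound 1 `Nc1ncnn2c([C@@H]3O[C@H](CO)[C@@H](O)[C@H]3O)cc(C#CC3CC3)c12` gives 40 nM
compound 2 `Nc1ncnn2c([C@@H]3O[C@H](CO)[C@@H](O)[C@H]3O)cc(C#Cc3ccccc3)c12` gives > 100000 nM as a limit
compound 3 `Nc1ncnn2c([C@@H]3O[C@H](CO)[C@@H](O)[C@H]3O)cc(-c3ccc(F)cc3)c12` gives > 100000 nM as a limit

Compound 3 stands on no number in a functional assay on K562 cells (Homo sapiens) for antiproliferative activity, with a stated time of 72 h (on this read-out lower numbers stand for stronger inhibition and higher numbers for weaker inhibition), but on a limit, > 100000 nM as reported. Compound 4 `COc1ccc(-c2cc([C@@H]3O[C@H](CO)[C@@H](O)[C@H]3O)n3ncnc(N)c23)cc1` has methoxy in place of fluoro on an aromatic carbon, para to a large group. The count reads methoxy in place of fluoro on an aromatic carbon for this change. Within the data shown here, no measured step touches this substituent. The nearest are an at least 2500-fold higher number from compound 1 to compound 3 (3.39 log units; beyond the scatter) and also an at least 2500-fold higher number from compound 1 to compound 2 (3.39 log units; beyond the scatter) and both are large, yet both remove the cyclopropyl-bearing alkyne, a group absent from compound 4 as well. The step that the two limits leave unreadable from compound 2 to compound 3 stays unreadable between its two limits. In this assay no step beyond the scatter is therefore expected, in either direction. The estimated change is an at least 1.4-fold lower number from compound 3 to compound 4 (0.15 log units; that floor lies within the scatter) in all likelihood. Compound 4 is expected near 70000 nM with an estimated range of 10000 nM to 100000 nM and quite possibly only a limit.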

Compound 4, half-maximal inhibitory concentration: 76400 nM
Estimate against measurement, compound 4: 1.1-fold (0.04 log units) below, and the stated range covers the measured number.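

In this assay the 4-methoxyphenyl group of compound 4 gives a measured number where the 4-fluorophenyl group of compound 3 gives only a limit, and that limit bounds what can be read here: the limit of > 100000 nM in this assay, at which 2 of the 4 values shown sit. Methoxy in place of fluoro gives an at least 1.3-fold lower number from compound 3 to compound 4 (0.11 log units; that floor lies within the scatter) and the swap from 2-phenylethynyl gives an at least 1.3-fold lower number from compound 2 to compound 4 (0.11 log units; that floor lies within the scatter); both are floors only, and the step between the two limits cannot be read. Compound 4 remains far from the 2-cyclopropylethynyl group, with a 1900-fold higher number from compound 1 to compound 4 (3.28 log units; beyond the scatter).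

Still open, as far as these compounds go, is whether a longer alkyl chain in place of cyclopropyl on the triple-bonded carbon keeps the activity of compound 1. Also open, from the compounds shown here alone, is whether an amine in place of methoxy moves compound 4 beyond the scatter.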